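The source may report more compounds than this note shows. Statements on the series, on what has been measured and on what is new or still open speak of the compounds shown alone.

In a functional assay on HT-29 cells (Homo sapiens) for inhibition, read by sulforhodamine B assay, with a stated time of 48 h (on this read-out higher numbers stand for weaker inhibition of growth and lower numbers for stronger inhibition of growth), three compounds sharing one core have been measured. Compound 1 `CC1=CC[C@H](C(C)(C)NC(=S)N/N=C/c2ccccc2O)CC1` carries a 2-hydroxyphenyl group on the carbon that is double-bonded to nitrogen, and in this assay compound 1 gives 16600 nM, the lowest number of the three. Compound 3 `CC1=CC[C@H](C(C)(C)NC(=S)N/N=C/c2cccc([N+](=O)[O-])c2)CC1` gives 21900 nM, which lies within the scatter of compound 1, so the two cannot be ranked. Among the compounds with values here, compound 2 `CC1=CC[C@H](C(C)(C)NC(=S)N/N=C/c2ccccc2[N+](=O)[O-])CC1` gives 70800 nM; the step of a 4.3-fold higher number from compound 1 to compound 2 (0.63 log units; beyond the scatter) is the only one beyond the scatter, and it is also the only step in which the hydroxy group is removed.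

Compound 4 `CC1=CC[C@H](C(C)(C)NC(=S)N/N=C/c2cccs2)CC1` has not yet been measured. It differs from compound 1 by thiophen-2-yl in place of 2-hydroxyphenyl on a carbon with a double bond to nitrogen. Within the data shown here, no measured pair brings in a thiophene ring, so the nearest guide is the step from compound 1 to compound 2, where the loss of the hydroxy group went with a modest weakening. The change to compound 4 removes that same hydroxy group and puts in a smaller ring, so a modest rise in the number, or none beyond the scatter, is expected rather than a large one. Compound 4 is therefore estimated at 25000 nM, with a range from 10000 nM to 60000 nM. The expected step is a 1.5-fold higher number from compound 1 to compound 4 (0.18 log units; within the scatter).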

Compound 4, concentration for total growth inhibition: 57800 nM
Compound 4: the middle estimate sits 2.3-fold (0.36 log units) below what was measured; the range from low to high includes it.
By their numbers in this assay, from the lowest: compounds 1 and 3 (each within the scatter of the next); then compounds 4 and 2 (each within the scatter of the next).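

In this assay, the change at this position gives a 3.5-fold higher number from compound 1 to compound 4 (0.54 log units; beyond the scatter), so a second, quite different replacement for 2-hydroxyphenyl also moves the number beyond the scatter, even though the entering thiophen-2-yl group is a smaller, five-membered ring with a sulfur atom. Compound 4 now sits within the scatter of compound 2, so two compounds without the hydroxy group share the weaker end of this small set, but compound 3, which also lacks that group, goes against any simple rule by staying within the scatter of compound 1. Nothing measured here explains why the number rises at this position, and these values alone give no cause for it.

Because the step to compound 4 changes the ring and removes the hydroxy group together, the compounds shown leave open which of the two goes with the rise. A plain phenyl group would test the loss of the hydroxy group on an unchanged ring, while a furan-2-yl group or a phenyl ring carrying an amine would show how far this position tolerates other groups.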